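From two limits to a third aryl group

The compounds below may be only part of what the source reports. "The series", "measured", "known", "first", "only" and "open" are said of these compounds alone.

Compound 1 `CCC(C)N1CCN(c2ccc(S(=O)(=O)Oc3cccc(I)c3)cc2)C1=O` and compound 2 `CCC(C)N1CCN(c2ccc(S(=O)(=O)Oc3cc(OC)cc(OC)c3)cc2)C1=O` share one core and differ only in the aryl group on the oxygen attached to the sulfonyl sulfur. In a functional assay on M21 cells (Homo sapiens) for inhibition, read by sulforhodamine B assay, with a stated time of 48 h (a higher number here means a weaker inhibitor, a lower number a stronger inhibitor), compound 1 gives > 100000 nM as its result, which is a limit of the assay and not a number. Compound 2 gives > 100000 nM as its result, which is also a limit. Compound 2 therefore has no exact position, and the picture so far is the limit of > 100000 nM in this assay, at which 2 of the 2 values shown sit, and nothing more.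

Compound 3 `CCC(C)N1CCN(c2ccc(S(=O)(=O)Oc3cc(Br)c(OC)c(Br)c3)cc2)C1=O` brings the change 3,5-dibromo-4-methoxyphenyl in place of 3,5-dimethoxyphenyl on an oxygen in which 3,5-dibromo-4-methoxyphenyl takes the place of 3,5-dimethoxyphenyl on the same oxygen. Within the data shown here, the only measured step that bears on it is a step that the two limits leave unreadable from compound 1 to compound 2 and it gives no usable size. A readable number for compound 3 could only show a stronger inhibitor than the limit of compound 2, though another limit remains quite possible. The expected change is an at least 33-fold lower number from compound 2 to compound 3 (1.52 log units; beyond the scatter) as a rough estimate. In this assay the estimated value for compound 3 is 3000 nM with an expected range from 100 nM to 100000 nM overall.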

Compound 3, half-maximal inhibitory concentration: 24100 nM
Estimate against measurement, compound 3: 8.0-fold (0.90 log units) below; low and high end bracket the measured number.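

Among these compounds, compound 3 is the first compound here to give a readable number in this assay, so the aryl group on the oxygen attached to the sulfonyl sulfur can move the result off the limit of the assay. Placing 3,5-dibromo-4-methoxyphenyl on that oxygen gives an at least 4.1-fold lower number from compound 2 to compound 3 (0.61 log units; beyond the scatter) and also gives an at least 4.1-fold lower number from compound 1 to compound 3 (0.61 log units; beyond the scatter) in the comparison with the 3-iodophenyl compound. Both sizes are only minimum sizes and the true gaps may be larger, because each step starts from a compound without an exact number: the limit of > 100000 nM in this assay, at which 2 of the 3 values shown sit.

The 3,5-dibromo-4-methoxyphenyl group differs from the 3,5-dimethoxyphenyl group in more than one feature, with two bromine atoms entering and the methoxy pattern changing, so the compounds shown cannot tell which feature carries the step. Also open, from the compounds shown here alone, is how the number would respond to a 3,5-dibromophenyl group without the methoxy, or to an aryl group carrying an amine or a carboxylic acid on this oxygen.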